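Benzoselenazole series: removing the iodo substituent

The source may hold more compounds than are shown below. What is called first, only, known or untested is meant among the compounds shown, and "the series" means these compounds.

Compound 1 `Ic1nc2ccccc2[se]1` is assessed in a functional assay on HCT-116 cells (Homo sapiens) for cytotoxicity, with a stated time of 3 days (a higher number here means a weaker inhibitor, a lower number a stronger inhibitor), where compound 1 gives > 40000 nM, a limit of the assay rather than a number. Compound 2 `Ic1nc2ccccc2o1` likewise gives > 40000 nM in this assay, again a limit. Compound 3 `C#Cc1sc(-c2ccc(F)cc2)nc1C(=O)OCC` gives > 40000 nM in this assay, also a limit. Compound 1 thus stands at the limit of > 40000 nM in this assay, at which 3 of the 3 values shown sit, with no measured number to separate it from the other two. Among the measured compounds shown here, no step between measured compounds is available. Compound 4 `c1ccc2[se]cnc2c1` is the next member; it differs from compound 1 by hydrogen in place of iodo on an aromatic carbon. For the measured compounds named here, with no measured step to lean on, the change is expected to be none beyond the scatter, a number no higher from compound 1 to compound 4 (the limit leaves the size open). Compound 4 is therefore expected to give 40000 nM in this assay, between 15000 nM and 100000 nM, most likely reported only as a limit once more.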

Compound 4, half-maximal inhibitory concentration: > 40000 nM
Compound 4 ended at the assay's limit; the forecaster's own chance of this, stated with the estimate: 80%; the middle value sits exactly at the limit.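

No step can be read between compound 1 and compound 4 in this assay, since both stand at a limit of the assay: the limit of > 40000 nM in this assay, at which 4 of the 4 values shown sit. As far as these compounds go, whether hydrogen in place of iodo changes cytotoxicity at all stays open.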